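From 2-hydroxyethyl to 3-(dimethylamino)propyl at the assay limit

A few compounds are considered here, and "the series" means these few. Any claim that something is new, unique, unknown or untested is made for them only; others in the source may bear on it.

Values in a functional assay on HL60/MX2 cells (Homo sapiens) for antiproliferative activity, read by MTT assay, with a stated time of 48 h; on this read-out lower numbers stand for stronger inhibition and higher numbers for weaker inhibition:
Compound 1 `N#Cc1nc2c(-c3nc4ccccc4[nH]3)c(N)n(CCN3CCCC3)c2nc1C#N`: > 50000 nM (a limit)
Compound 2 `N#Cc1nc2c(-c3nc4ccccc4[nH]3)c(N)n(CCO)c2nc1C#N`: > 50000 nM (a limit)

In this assay compound 2 reads > 50000 nM, which is a limit and not a number. Both compounds share (the limit of > 50000 nM in this assay, at which 2 of the 2 values shown sit). Compound 3 `CN(C)CCCn1c(N)c(-c2nc3ccccc3[nH]2)c2nc(C#N)c(C#N)nc21` carries (dimethylamino)methyl in place of hydroxy on a saturated chain carbon, two bonds along the chain from an aromatic nitrogen. Among the measured compounds shown here, the only measured step is a step that the two limits leave unreadable from compound 1 to compound 2, so it offers no size to carry over. Compound 1, which has a pyrrolidin-1-yl group on its chain, gives > 50000 nM, also a limit, so another limit is expected. The estimated step is a number no higher from compound 2 to compound 3 (the limit leaves the size open), with no firm direction expected in this assay. For compound 3 the estimate is 50000 nM, with an expected range of 15000 nM to 80000 nM.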

Compound 3, half-maximal inhibitory concentration: 2390 nM
Beside the measured number, compound 3's estimate is 21-fold (1.32 log units) above it; measured number below the stated range.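

Among the compounds shown here, the end of the chain at this position can move the read-out in this assay: 3-(dimethylamino)propyl in place of 2-hydroxyethyl gives the first value in the set that is a number rather than a limit (an at least 20-fold lower number from compound 2 to compound 3 (1.32 log units; beyond the scatter)). An amine on the chain is not enough by itself, as compound 1 carries pyrrolidin-1-yl and stays at a limit (an at least 20-fold lower number from compound 1 to compound 3 (1.32 log units; beyond the scatter)).

Compound 3 differs from both in its chain length and its end group, so the two contributions remain unseparated. A 3-(pyrrolidin-1-yl)propyl or 2-(dimethylamino)ethyl chain would tell them apart.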